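The source may hold more compounds than are shown below. What is called first, only, known or untested is meant among the compounds shown, and "the series" means these compounds.

Measured in an ADME assay on RAW264.7 cells (Mus musculus) for cytotoxicity, read by MTT assay, with a stated time of 72 h, tested at 50 uM; on this read-out higher numbers stand for a stronger effect at the one concentration tested and lower numbers for a weaker effect:
- compound 1, `O=C(Cn1c(=O)oc2cc(Cl)ccc21)Nc1ccccc1`: 15.8%
- compound 2, `O=C(Cn1c(=O)oc2cc(Cl)ccc21)NCc1ccco1`: 27.8%
- compound 3, `O=C(Cn1c(=O)oc2cc([N+](=O)[O-])ccc21)NCc1ccco1`: 26.8%

Compound 2 gives the highest of the three numbers in this assay; compound 3 sits within the scatter of it, and only compound 1 lies beyond the scatter, a number 12 percentage points higher from compound 1 to compound 2 (beyond the scatter). The swap of chloro for nitro on the core, a number 1 percentage points lower from compound 2 to compound 3 (within the scatter), changed nothing that can be told from the scatter.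

Compound 4, `O=C(Cn1c(=O)oc2cc(Cl)ccc21)Nc1ccccn1`, is not yet measured. It differs from compound 2 at the amide-type nitrogen: pyridin-2-yl in place of (furan-2-yl)methyl on an amide-type nitrogen. Among the measured compounds shown here, the one measured step that bears on this is the move from compound 1 to compound 2, where an aromatic ring bound directly to the amide-type nitrogen gave way to a ring carried on a methylene, and the number rose modestly. Compound 4 returns to a ring bound directly to that nitrogen, so a modest fall in this assay is expected, a number 9.8 percentage points lower from compound 2 to compound 4 (within the scatter). Compound 3 gives no further guidance here. For compound 4 the estimate is 18%, with a range from 8% to 30%, pending the actual reading.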

Compound 4, a percentage reported as inhibition, at one concentration (the size of the read-out at that concentration, not a potency): 33%
Compound 4: the middle estimate sits 15 percentage points below what was measured; measured number outside the range, above it.
By their numbers in this assay, from the lowest: compound 1; then compounds 3, 2 and 4 (each within the scatter of the next).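

At the amide-type nitrogen, a ring bound directly does not by itself go with the low number in this assay: pyridin-2-yl in place of phenyl gives a number 17.2 percentage points higher from compound 1 to compound 4 (beyond the scatter), so the identity of the ring counts here as well as how it is attached. Set against the ring carried on a methylene, the same group gives a number 5.2 percentage points higher from compound 2 to compound 4 (within the scatter), so these two groups cannot be told apart in this read-out, and compound 1 alone stands apart from them. Nothing available accounts for either step.

Open, from the compounds shown here alone, is whether a (pyridin-2-yl)methyl group on the amide-type nitrogen would stay with compound 2 and compound 4 or move away from them. Also open, going by these compounds, is what a non-aromatic group, such as a cyclohexyl ring or a butyl chain, would give at this nitrogen.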